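The source may hold more compounds than are shown below. What is called first, only, known or untested is meant among the compounds shown, and "the series" means these compounds.

Four compounds built on one shared core appear here. Compound 1 `CCCCNC(=O)N1CC1C#N` carries a butyl chain on the urea nitrogen. In a functional assay on MCF7 cells (Homo sapiens) for inhibition (a lower number here means a stronger inhibitor, a higher number a weaker inhibitor), compound 1 reaches only a limit of > 12000 nM, not a number. Compound 2 `N#CC1CN1C(=O)Nc1ccc(F)cc1` gives 1900 nM in this assay, the lowest of the two numbers measured. Compound 3 `N#CC1CN1C(=O)NC1CCCCC1` gives 13000 nM in this assay, a gap from compound 2 that lies beyond the usual scatter. Compound 4 `N#CC1CN1C(=O)Nc1ccc(S(N)(=O)=O)cc1` has not been measured; it differs from compound 2 by sulfamoyl in place of fluoro on an aromatic carbon. Within the data shown here, no measured pair shows this change, so the expected step of a 1.8-fold higher number from compound 2 to compound 4 (0.27 log units; within the scatter) in this assay is small and uncertain, leaning weaker. Compound 4 is estimated at 3500 nM, in a range from 900 nM to 13000 nM.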

Compound 4, half-maximal inhibitory concentration: > 15000 nM
Compound 4 ended at the assay's limit; the forecaster's own chance of this, stated with the estimate: 20%; middle value at least 4.2-fold (0.63 log units) from the limit.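

Among these compounds, replacing fluoro with sulfamoyl at this aromatic carbon gives an at least 7.8-fold higher number from compound 2 to compound 4 (0.89 log units; beyond the scatter) in this assay, the first sign that the group at this position can weaken inhibition of this kind. Compound 4 gives no number, only a limit: the limit of > 15000 nM in this assay, at which 1 of the 4 values shown sits. Among the compounds shown here, the full size of the loss stays unknown, and fluoro is the only group here at this position with a measured number.

Whether the loss is particular to sulfamoyl stays open, with only fluoro and sulfamoyl shown at this position. A chloro, methyl or carboxylic acid group there would test it.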